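The source may hold more compounds than are shown below. What is called first, only, known or untested is meant among the compounds shown, and "the series" means these compounds.

Compound 1 `CC(=O)N1N=C(c2ccc(O)cc2)CC1c1ccccc1Cl` is the weaker of the two measured compounds: in an assay on isolated protein for inhibition of Monoamine oxidase (Homo sapiens) (on this read-out lower numbers stand for stronger inhibition and higher numbers for weaker inhibition), compound 1 gives 50000 nM, the highest number of the two, while compound 2 `CC(=O)N1N=C(c2ccc(O)cc2)CC1c1ccc(C)cc1` gives 200 nM in this assay. Among the measured compounds shown here, the one measured step, a 250-fold lower number from compound 1 to compound 2 (2.40 log units; beyond the scatter), shows how much a change on the phenyl ring attached to the saturated ring carbon can matter, though it alters both the group and its position at once.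

Compound 3 `COc1ccccc1C1CC(c2ccc(O)cc2)=NN1C(C)=O` differs from compound 1 in a single place: methoxy in place of chloro on an aromatic carbon. Here the group keeps its position ortho to the large group, and only the chloro is replaced by a methoxy, so the measured step bears on it only loosely. Given that compound 1 gives 50000 nM and that the one step from it was large and downward, a moderate downward step is expected for compound 3, estimated as a 4.2-fold lower number from compound 1 to compound 3 (0.62 log units; beyond the scatter), with wide uncertainty because the change at hand is smaller than the one actually measured. Compound 3 is therefore estimated at 12000 nM in this assay, within a range from 2000 nM to 60000 nM.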

Compound 3, half-maximal inhibitory concentration: 30000 nM
Compound 3: the middle estimate sits 2.5-fold (0.40 log units) below what was measured; measured number inside the range.
By their numbers in this assay, from the lowest: compound 2; then compounds 3 and 1 (each within the scatter of the next).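

In this assay, methoxy in place of chloro on an aromatic carbon, ortho to a large group, gives a 1.7-fold lower number from compound 1 to compound 3 (0.22 log units; within the scatter), so at this position the two groups cannot be told apart. The earlier step, a 250-fold lower number from compound 1 to compound 2 (2.40 log units; beyond the scatter), changed the group and its position together, whereas this one keeps the position and swaps only the group, bringing in one more heavy atom and one hydrogen-bond acceptor without a change that stands out from the scatter. No independent measurement is available to explain this result.

As far as these compounds go, it remains open how much of the large step to compound 2 belongs to the group and how much to its position, a question that a methyl at the place held by chloro in compound 1 would help to answer. From the compounds shown here alone, it also remains open whether this position tolerates only groups like chloro and methoxy or responds to quite different ones, such as an amine, a carboxylic acid or a longer chain like butoxy.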